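Chloro to Fluoro on Two Related Cores

The source may report more compounds than this note shows. Statements on the series, on what has been measured and on what is new or still open speak of the compounds shown alone.

The measured compounds and their values in an assay on isolated protein for binding affinity to 5-hydroxytryptamine receptor 6 (Homo sapiens); on this read-out lower numbers stand for stronger inhibition and higher numbers for weaker inhibition:
compound 1, `Clc1ccc(-c2n[nH]cc2N2CCCNCC2)cc1`: compound 1 gives 1090 nM
compound 2, `Fc1ccc(-c2n[nH]cc2N2CCCNCC2)cc1`: compound 2 gives 2290 nM
compound 3, `Clc1cccc(-c2n[nH]cc2N2CCNCC2)c1`: compound 3 gives 109 nM

Compound 3 stands at the lowest of the three numbers; compound 1 is nearest to it and compound 2 furthest. How the core of compound 3 differs from the core of compound 1 is not broken down here.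

Within the core of compound 1, the change from compound 1 to compound 2 is fluoro in place of chloro on an aromatic carbon. In this assay it gave a 2.1-fold higher number from compound 1 to compound 2 (0.32 log units; beyond the scatter).

Compound 4, `Fc1cccc(-c2n[nH]cc2N2CCNCC2)c1`, has not yet been measured in this assay. It differs from compound 3 by fluoro in place of chloro on an aromatic carbon. Among the measured compounds shown here, this is the same kind of change as the one from compound 1 to compound 2, though the place is not the same word for word: in compound 2 the fluoro sits para to a large group, in compound 4 meta to a large group.

With one example of this change, the expectation for compound 4 rests on that single step and on the value of compound 3, and the step from compound 3 to compound 4 is estimated at a 2.1-fold higher number from compound 3 to compound 4 (0.32 log units; beyond the scatter), beside the earlier one. Compound 4 is therefore expected to give about 230 nM in this assay, with a plausible range from 110 nM to 500 nM.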

Compound 4, inhibition constant: 162 nM
Beside the measured number, compound 4's estimate is 1.4-fold (0.15 log units) above it, within the range that was stated.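

Fluoro in place of chloro gave a 1.5-fold higher number from compound 3 to compound 4 (0.17 log units; within the scatter) in this assay, so this pair shows no difference that can be read apart from the usual variation between repeats. Set beside the earlier step, the change carries over from one core to the other with no gap that can be told from scatter: the same change on two cores in this assay, a 2.1-fold higher number (0.32 log units; beyond the scatter) from compound 1 to compound 2 and a 1.5-fold higher number (0.17 log units; within the scatter) from compound 3 to compound 4, 1.4-fold (0.15 log units) apart, within the scatter of two such steps. Among the compounds shown here, this supports using the step seen on one core as a rough guide on the other, but it rests on only two pairs, one step beyond the scatter and one within it, and the group sits in a different place in each pair, so it does not show that the change has the same size across the series or what lies behind it.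

The compounds shown leave open whether the step would stay the same with the halogen in one and the same place on both cores, a comparison that would separate the effect of the core from that of the place. They also leave open how a bromo, methyl, methoxy or nitrile group in the place of chloro would compare on either core.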